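From 2-fluorophenyl to 4-fluorophenyl among limit values

The compounds below may be only part of what the source reports. "The series", "measured", "known", "first", "only" and "open" are said of these compounds alone.

In a functional assay on MDA-MB-231 cells (Homo sapiens) for antiproliferative activity, read by MTT assay, with a stated time of 24 h (a lower number here means a stronger inhibitor, a higher number a weaker inhibitor), compound 1 `Cc1ccccc1NNC(=O)c1ccccc1NS(=O)(=O)c1cnc(O)nc1O` gives only a limit, > 20000 nM. Compound 2 `Cc1ccc(C(=O)NNC(=O)c2ccccc2NS(=O)(=O)c2cnc(O)nc2O)cc1` also gives only a limit, > 20000 nM. Compound 3 `O=C(NNC(=O)c1ccccc1NS(=O)(=O)c1cnc(O)nc1O)c1ccccc1F` likewise gives only a limit, > 20000 nM. The series therefore stands at the limit of > 20000 nM in this assay, at which 3 of the 3 values shown sit.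

Compound 4 `O=C(NNC(=O)c1ccccc1NS(=O)(=O)c1cnc(O)nc1O)c1ccc(F)cc1` carries 4-fluorophenyl in place of 2-fluorophenyl on a carbonyl carbon. The nearest measured changes are a step that the two limits leave unreadable from compound 2 to compound 3 and a step that the two limits leave unreadable from compound 1 to compound 3, so neither provides a size to carry over. With only the limit of > 20000 nM in this assay, at which 3 of the 3 values shown sit, to rest on, no change beyond the usual scatter is expected, and the expected step is a step that the limit leaves unreadable from compound 3 to compound 4. The estimate for compound 4 is 25000 nM, within an estimated range of 12000 nM to 50000 nM.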

Compound 4, half-maximal inhibitory concentration: > 20000 nM
Compound 4 gave a limit, no number (the forecaster's own chance of this, stated with the estimate: 85%); the middle value lies beyond the limit too.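

The steps from compound 1, compound 2 and compound 3 to compound 4 cannot be read in this assay, since every value is a limit: the limit of > 20000 nM in this assay, at which 4 of the 4 values shown sit.

Whether any of these changes alters the activity, and in which direction, stays open among the compounds shown.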